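The source may hold more compounds than are shown below. What is called first, only, known or untested is meant among the compounds shown, and "the series" means these compounds.

Measured compounds:
- compound 1, `COc1cc2c(Oc3ccc(NC(=O)c4cn(-c5ccccc5F)nn4)cc3F)ccnc2cc1OCCCN1CCCCC1`, 1290 nM
- compound 2, `COc1cc2c(Oc3ccc(NC(=O)c4cn(-c5ccccc5F)nn4)cc3F)ccnc2cc1OCCCN1CCC(C)CC1`, 130 nM
- compound 3, `COc1cc2c(Oc3ccc(NC(=O)c4cn(-c5ccccc5)nn4)cc3F)ccnc2cc1OCCCN1CCN(C)CC1`, 60 nM

In a functional assay on MKN-45 cells (Homo sapiens) for cytotoxicity, read by MTT assay, with a stated time of 72 h (a higher number here means a weaker inhibitor, a lower number a stronger inhibitor), compound 3 gives the lowest number of the three; compound 2 stands nearest, and compound 1 furthest from it. Going by the values given here, the only single-point step among the measured compounds, a 9.9-fold lower number from compound 1 to compound 2 (1.00 log units; beyond the scatter), concerns the saturated ring and not the aromatic ring that changes here.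

Compound 4, `COc1cc2c(Oc3ccc(NC(=O)c4cn(-c5ccccc5F)nn4)cc3F)ccnc2cc1OCCCN1CCN(C)CC1`, differs from compound 3 in one place: fluoro in place of hydrogen on an aromatic carbon. Among the compounds with values here, compounds 1 and 2 already carry the 2-fluorophenyl group, but each of them also differs from compound 3 in the saturated ring, so no measured pair isolates this fluoro for hydrogen exchange. With nothing in the data speaking directly to it, the step of a 1.1-fold lower number from compound 3 to compound 4 (0.04 log units; within the scatter) is expected to stay within the scatter of this assay, in no clear direction.

Compound 4 is therefore estimated at 55 nM in this assay, with a range from 20 nM to 160 nM.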

Compound 4, half-maximal inhibitory concentration: 140 nM
For compound 4 the middle estimate is 2.5-fold (0.41 log units) below the measured one, and the stated range covers the measured number.
By their numbers in this assay, from the lowest: compound 3; then compounds 2 and 4 (each within the scatter of the next); then compound 1.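

In this assay, the exchange of hydrogen for fluoro on this aromatic carbon, ortho to a large group, can now be read on its own: phenyl to 2-fluorophenyl is a modest step against potency (a 2.3-fold higher number from compound 3 to compound 4 (0.37 log units; beyond the scatter)). With the 2-fluorophenyl group held constant, the saturated ring can also be compared across three forms: 4-methylpiperazin-1-yl cannot be told apart from 4-methylpiperidin-1-yl (a 1.1-fold higher number from compound 2 to compound 4 (0.03 log units; within the scatter)), while it stands clearly apart from piperidin-1-yl (a 9.2-fold lower number from compound 1 to compound 4 (0.96 log units; beyond the scatter)). The data offer no measurement that explains either finding.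

Open, going by these compounds, is whether the fluoro step would look the same with piperidin-1-yl or 4-methylpiperidin-1-yl on the chain. Also open, on these data alone, is how chloro or methoxy on that aromatic carbon, or morpholin-4-yl on the chain, would compare.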